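A few compounds are considered here, and "the series" means these few. Any claim that something is new, unique, unknown or untested is made for them only; others in the source may bear on it.

Measured compounds:
compound 1 `Cn1c(Cc2nn(C)c(=O)c3ccccc23)nnc1SCCCC(=O)Nc1ccc(Cl)cc1Cl` — 9800 nM
compound 2 `Cn1c(Cc2nn(C)c(=O)c3ccccc23)nnc1SCC(=O)Nc1ccc(O)cc1` — "not active" (no number reported)
compound 3 `Cn1c(Cc2nn(C)c(=O)c3ccccc23)nnc1SCCCCCCCCCC(=O)Nc1ccc(Cl)cc1Cl` — 2300 nM

All three share one core and differ in the chain and the amide aryl group on the sulfur side. In an assay on isolated protein (Mus musculus) for inhibition of IL15-IL15 receptor (Homo sapiens), read by resazurin assay, with stated times of 30 min and 2.5 days (a lower number here means a stronger inhibitor, a higher number a weaker inhibitor), compound 1 gives 9800 nM and compound 3 gives 2300 nM; compound 3 thus holds the lowest number of the two, with compound 1 higher by a margin beyond the scatter. Compound 2 gives "not active" (no number reported) in this assay, so no number stands for it.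

Compound 4 `CCCCCCCCCCSc1nnc(Cc2nn(C)c(=O)c3ccccc23)n1C` is not yet measured. It differs from compound 3 in one place: methyl in place of (2,4-dichlorophenyl)carbamoyl on a saturated chain carbon, nine bonds along the chain from a sulfur. The amide and the dichlorophenyl ring are gone; what remains is a plain chain on the sulfur.

For the measured compounds named here, no measured pair shows this kind of change, so the direction rests on comparison alone. Going by the values given here, compounds 1 and 3 both carry the (2,4-dichlorophenyl)carbamoyl end and are the only ones with numbers; compound 2, with a different aryl amide, gave nothing. Removing the whole carbamoyl-aryl end is expected to give a weaker inhibitor, with a step of a 3.0-fold higher number from compound 3 to compound 4 (0.48 log units; beyond the scatter) estimated beyond the scatter. For compound 4 the expected value is 7000 nM, within a range from 1500 nM to 30000 nM.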

Compound 4, half-maximal inhibitory concentration: 7600 nM
For compound 4 the middle estimate is 1.1-fold (0.04 log units) below the measured one; the range from low to high includes it.
By their numbers in this assay, from the lowest: compound 3; then compounds 4 and 1 (each within the scatter of the next).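

In this assay the (2,4-dichlorophenyl)carbamoyl end on the long chain of compound 3 can give way to methyl with a 3.3-fold higher number from compound 3 to compound 4 (0.52 log units; beyond the scatter), a modest step, so a plain chain on the sulfur with no amide and no aryl ring still returns a number in this assay. Heptyl in place of (2,4-dichlorophenyl)carbamoyl, three bonds along the chain from a sulfur, gives a 1.3-fold lower number from compound 1 to compound 4 (0.11 log units; within the scatter) and so stays within the scatter: on the shorter chain of compound 1, that end shows no measurable advantage over the plain chain of compound 4. No measured evidence bears on the origin of either step.

The compounds shown leave open how the plain chain behaves as it is shortened or lengthened, since a hexyl or a dodecyl chain on the sulfur would separate chain length from the presence of the end group. Also open, from the compounds shown here alone, is whether a small polar end on the same chain, such as a carboxylic acid, an amine or a simple primary amide, would hold, improve or lose the number seen for compound 4.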